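Catechol for chloro on the thiazolethione: an estimate

This account rests on a few compounds, and the source may have more. Where it says the series, first, only, none or still open, it means among the compounds named here.

Compound 1 `COc1cc(N2C(=S)SCC2(O)c2ccc(Br)cc2)cc(OC)c1OC` gives, in a functional assay on T47D cells (Homo sapiens) for cytotoxicity, read by MTT assay, with a stated time of 48 h (a higher number here means a weaker inhibitor, a lower number a stronger inhibitor), 16.3 ug/mL.
Compound 2 `COc1cc(-n2c(-c3ccc(Cl)cc3)csc2=S)cc(OC)c1OC` gives in this assay only a limit, > 100 ug/mL.
Compound 3 `COc1cc(-n2c(-c3ccc(-c4ccccc4)cc3)csc2=S)cc(OC)c1OC` likewise gives only a limit, > 100 ug/mL.

Compound 2 therefore stands at the limit of > 100 ug/mL in this assay, at which 2 of the 3 values shown sit, and no number is attached to it. Among the compounds with values here, the one measured step on its core, a step that the two limits leave unreadable from compound 2 to compound 3, cannot be read. Compound 4 `COc1cc(-n2c(-c3ccc(O)c(O)c3)csc2=S)cc(OC)c1OC` carries 3,4-dihydroxyphenyl in place of 4-chlorophenyl on an aromatic carbon. Within the data shown here, no measured step bears on this exchange, so the direction of the change in this assay is open. Compound 4 is expected to give 100 ug/mL, within the range 30 ug/mL to 300 ug/mL. The expected step is a number no higher from compound 2 to compound 4 (the limit leaves the size open), most likely again ending at the limit rather than at a number.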

Compound 4, half-maximal inhibitory concentration: 24.9 ug/mL
Beside the measured number, compound 4's estimate is 4.0-fold (0.60 log units) above it; the measured number lies below the stated range.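

In this assay, 3,4-dihydroxyphenyl in place of 4-chlorophenyl, on the aromatic carbon next to the ring nitrogen, gives an at least 4.0-fold lower number from compound 2 to compound 4 (0.60 log units; beyond the scatter). Within the data shown here, this is the only readable step on the shared core, since the step from 4-chlorophenyl to the phenyl-bearing group of compound 3 cannot be read, and it shows that a change at this position can bring a number within reach of the assay. Its full size stays open because compound 2 has only a limit: the limit of > 100 ug/mL in this assay, at which 2 of the 4 values shown sit.

The compounds shown leave open whether a single hydroxyl, an amine or a carboxylic acid at this position would also give a number rather than a limit.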